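This account rests on a few compounds, and the source may have more. Where it says the series, first, only, none or still open, it means among the compounds named here.

Measured in a functional assay on VCaP cells (Homo sapiens) for antiproliferative activity, read by CCK-8 assay, with a stated time of 6 days; on this read-out higher numbers stand for weaker inhibition and lower numbers for stronger inhibition:
- compound 1 `Cc1noc(C)c1-c1cccc(Oc2ccc(C#N)c(C(F)(F)F)c2)c1`: "not determined" (no result reported)
- compound 2 `N#Cc1ccc(N2CCc3cc(-c4cncnc4)ccc32)cc1C(F)(F)F`: "not determined" (no result reported)
- compound 3 `CCN(c1ccc(C#N)c(Cl)c1)c1cc(-n2cnc3ccccc32)ccc1C`: 8560 nM

Of these three entries, only compound 3 carries a number, so it has no measured neighbour to be ranked against. Compound 1 and compound 2 have no result that could place it as strong or weak within the set.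

The next compound is compound 4 `CCN(c1ccc(C#N)c(Cl)c1)c1cc(C2=CCCCC2)ccc1C`, which keeps the core of compound 3 and swaps one substituent on an aromatic carbon, with cyclohex-1-en-1-yl in place of 1H-benzimidazol-1-yl on an aromatic carbon.

Going by the values given here, no pair of measured compounds differs in one place, so the data hold no precedent for this change. Among the compounds with values here, the only anchor is compound 3 at 8560 nM. No step beyond the usual scatter is therefore expected in this assay, with a slight lean towards stronger inhibition. The expected change is a 1.4-fold lower number from compound 3 to compound 4 (0.15 log units; within the scatter).

For compound 4 the estimated value is 6000 nM, with an expected range from 1500 nM to 20000 nM.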

Compound 4, half-maximal inhibitory concentration: 20000 nM
Estimate against measurement, compound 4: 3.3-fold (0.52 log units) below, and the stated range covers the measured number.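

In this assay, going by these compounds alone, this is the first step in the set that can be read, and it shows that the aromatic carbon meta to a large group and para to a methyl group is sensitive to what it carries. Putting cyclohex-1-en-1-yl in place of 1H-benzimidazol-1-yl gives a 2.3-fold higher number from compound 3 to compound 4 (0.37 log units; beyond the scatter), a modest weakening of inhibition that lies beyond the usual scatter. No measured property of either group is available to account for this step.

The change replaces the aromatic rings, the nitrogen atoms and the hydrogen-bond acceptors in a single move, so these compounds do not separate their contributions. As far as these compounds go, it remains open how a phenyl group or a pyridin-3-yl group would compare at this same position.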